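Changing the aryl group on the saturated ring carbon

The source may hold more compounds than are shown below. What is called first, only, known or untested is meant among the compounds shown, and "the series" means these compounds.

In an assay on microsomes for inhibition of acyl-CoA:cholesterol acyltransferase (Oryctolagus cuniculus) (on this read-out lower numbers stand for stronger inhibition and higher numbers for weaker inhibition), compound 2 `CC(C)c1cccc(C(C)C)c1NC(=O)NCC1(c2ccc([N+](=O)[O-])cc2)CCCC1` gives 131 nM. Compound 1 `CC(C)c1cccc(C(C)C)c1NC(=O)NCC1(c2ccc(CC(C)(C)C)cc2)CCCC1` gives 159 nM in this assay, and the step of a 1.2-fold lower number from compound 1 to compound 2 (0.08 log units; within the scatter) lies within the scatter, so the two stand at the same level. Compound 3 `COC(=O)c1cccc(C2(CNC(=O)Nc3c(C(C)C)cccc3C(C)C)CCCC2)c1` differs from compound 2 by 3-(methoxycarbonyl)phenyl in place of 4-nitrophenyl on a saturated ring carbon. For the measured compounds named here, the only measured step, from compound 1 to compound 2, also exchanged the group on that aromatic ring and stayed within the scatter; on that basis no step beyond the scatter is expected here, a 1.1-fold higher number from compound 2 to compound 3 (0.06 log units; within the scatter). Compound 3 is therefore expected near 150 nM, between 60 nM and 400 nM.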

Compound 3, half-maximal inhibitory concentration: 34 nM
Compound 3: middle estimate off by 4.4-fold (0.64 log units), on the high side; the whole stated range lies above it.
By their numbers in this assay, from the lowest: compound 3; then compounds 2 and 1 (each within the scatter of the next).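

In this assay, the aryl group on the saturated ring carbon clearly can shift the number: 3-(methoxycarbonyl)phenyl gives a 3.9-fold lower number from compound 2 to compound 3 (0.59 log units; beyond the scatter) against 4-nitrophenyl and a 4.7-fold lower number from compound 1 to compound 3 (0.67 log units; beyond the scatter) against 4-neopentylphenyl, although the exchange between those two groups stayed within the scatter. This change replaces both the substituent and its numbered position on the aromatic ring, so the two contributions cannot be separated. No measurement at hand accounts for the step.

Still open, as far as these compounds go, is how 4-(methoxycarbonyl)phenyl would stand, and how a carboxylic acid in place of the methoxycarbonyl group would compare.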